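Naphthyl for fluorophenyl on the thiourea nitrogen of compound 3

The source may report more compounds than this note shows. Statements on the series, on what has been measured and on what is new or still open speak of the compounds shown alone.

Measured compounds:
Compound 1 `CN(c1cc2ncc(=O)[nH]c2cc1NC(=S)NC(=O)/C=C/c1ccccc1)C1CCCCC1`: 11000 nM
Compound 2 `CN(c1cc2ncc(=O)[nH]c2cc1NC(=S)Nc1ccccc1)C1CCCCC1`: 49600 nM
Compound 3 `CN(c1cc2ncc(=O)[nH]c2cc1NC(=S)Nc1ccc(F)cc1)C1CCCCC1`: 64300 nM

In an ADME assay on Huh-7 cells (Homo sapiens) for cytotoxicity (on this read-out lower numbers stand for stronger inhibition and higher numbers for weaker inhibition), compound 3 gives the highest of the three numbers. Its nearest neighbour is compound 2, the step of a 1.3-fold higher number from compound 2 to compound 3 (0.11 log units; within the scatter) lying within the scatter; its furthest is compound 1, the step of a 5.8-fold higher number from compound 1 to compound 3 (0.77 log units; beyond the scatter) being beyond it. Compound 4 `CN(c1cc2ncc(=O)[nH]c2cc1NC(=S)Nc1cccc2ccccc12)C1CCCCC1` differs from compound 3 by naphthalen-1-yl in place of 4-fluorophenyl on an amide-type nitrogen. Among the measured compounds shown here, no measured step exchanges one aryl group on this nitrogen for a larger one; the nearest comparisons are the step of a 1.3-fold higher number from compound 2 to compound 3 (0.11 log units; within the scatter), which alters the same ring only by a fluoro for hydrogen exchange, and the steps of a 4.5-fold higher number from compound 1 to compound 2 (0.65 log units; beyond the scatter) and a 5.8-fold higher number from compound 1 to compound 3 (0.77 log units; beyond the scatter), which replace the (2-phenylethenyl)carbonyl group with aryl groups at the same place. These show that changes at this nitrogen move this assay by modest amounts at most. Compound 4 is therefore expected to give a number close to that of compound 3, with a somewhat lower value considered slightly more likely, so that the estimated step is a 1.6-fold lower number from compound 3 to compound 4 (0.21 log units; within the scatter). The estimate for compound 4 is 40000 nM, with a range from 15000 nM to 110000 nM.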

Compound 4, half-maximal inhibitory concentration: 43600 nM
Beside the measured number, compound 4's estimate is 1.1-fold (0.04 log units) below it, within the range that was stated.
By their numbers in this assay, from the lowest: compound 1; then compounds 4, 2 and 3 (each within the scatter of the next).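

In this assay, naphthalen-1-yl in place of 4-fluorophenyl on this amide-type nitrogen gives a 1.5-fold lower number from compound 3 to compound 4 (0.17 log units; within the scatter) and stays within the scatter, and naphthalen-1-yl in place of phenyl gives a 1.1-fold lower number from compound 2 to compound 4 (0.06 log units; within the scatter) and does the same, so a second aromatic ring on this nitrogen leaves the read-out where the single-ring aryl groups put it. The step beyond the scatter seen for the two single-ring aryl compounds now recurs with a two-ring aryl group as a 4.0-fold higher number from compound 1 to compound 4 (0.60 log units; beyond the scatter) and so, among the compounds shown, separates (2-phenylethenyl)carbonyl from all three aryl groups, whatever their size. Nothing available explains why these aryl groups read alike or why compound 1 stands apart from them.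

The compounds shown leave open whether this flat response holds for groups other than plain aryl rings on this nitrogen, such as a phenyl ring carrying an amine or a carboxylic acid, or a longer alkyl chain. They also leave open whether the carbonyl or the 2-phenylethenyl part sets compound 1 apart, which a simple acetyl group at the same nitrogen could help to separate.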